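The compounds below may be only part of what the source reports. "The series", "measured", "known", "first", "only" and "open" are said of these compounds alone.

Compound 1 `Cc1ccc(N2CCN/C2=N\N)cc1` and compound 2 `COc1ccc(N2CCN/C2=N\N)cc1` share one core, and in an ADME assay on Vero cells (Chlorocebus sabaeus) for cytotoxicity, with a stated time of 72 h, tested at 50 ug/mL (a higher number here means a stronger effect of the compound at the concentration tested, a lower number a weaker effect), compound 1 gives 9%, while compound 2 gives 0%. The step between them, (methoxy in place of methyl on an aromatic carbon), makes a number 9 percentage points lower from compound 1 to compound 2 (within the scatter). Compound 3 `Cc1ccccc1N1CCn2c1n[nH]c(=O)c2=O` has a different core; how the two cores differ is not broken down here. In this assay compound 3 gives 0%. Compound 4 `COc1ccccc1N1CCn2c1n[nH]c(=O)c2=O` carries the same kind of change on the core of compound 3, (methoxy in place of methyl on an aromatic carbon), though here the place is ortho to a large group rather than para to a group of 7 heavy atoms. Since compound 3 sits at 0% and the earlier step was within the scatter, the step from compound 3 to compound 4 is expected to be a number 2 percentage points higher from compound 3 to compound 4 (within the scatter). Compound 4 is therefore estimated at 2%, between 0% and 10%.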

Compound 4, a percentage reported as inhibition, at one concentration (the size of the read-out at that concentration, not a potency): 17%
Estimate against measurement, compound 4: 15 percentage points below, outside the stated range (above it).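

In this assay, methoxy in place of methyl on an aromatic carbon gives a number 17 percentage points higher from compound 3 to compound 4 (beyond the scatter). Set beside the earlier step, this shows that the same change does not carry over with the same result from one core to the other: the same change on two cores in this assay, a number 9 percentage points lower (within the scatter) from compound 1 to compound 2 and a number 17 percentage points higher (beyond the scatter) from compound 3 to compound 4, 26 percentage points apart, beyond the scatter of two such steps. Going by these compounds alone, it does not show whether the core or the place on the aromatic ring accounts for the gap, as the two pairs differ in both and each core offers only one pair.

Still open, as far as these compounds go, is whether methoxy and methyl at a matching place on both cores would give matching steps. Also open, from the compounds shown here alone, is how other groups there, such as an amine, a carboxylic acid or a longer chain, would read on either core.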